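The compounds below may be only part of what the source reports. "The series", "measured", "known", "first", "only" and "open" are said of these compounds alone.

Measured compounds:
compound 1, `COc1cc2c(Oc3ccc(NC(=O)c4cn(-c5c(C)cccc5C)nn4)cc3F)ccnc2cc1OCCCN1CCCC1`: 2240 nM
compound 2, `COc1cc2c(Oc3ccc(NC(=O)c4cn(-c5ccc(Br)cc5)nn4)cc3F)ccnc2cc1OCCCN1CCCCC1`: 260 nM

In a functional assay on HT-29 cells (Homo sapiens) for cytotoxicity, read by MTT assay, with a stated time of 72 h (a lower number here means a stronger inhibitor, a higher number a weaker inhibitor), compound 2 gives 260 nM, the lowest of the two numbers; compound 1 gives 2240 nM, a gap beyond the scatter. Compound 3, `COc1cc2c(Oc3ccc(NC(=O)c4cn(-c5c(C)cccc5C)nn4)cc3F)ccnc2cc1OCCCN1CCCCC1`, is not yet measured. It differs from compound 2 by 2,6-dimethylphenyl in place of 4-bromophenyl on an aromatic nitrogen. Within the data shown here, the entering group is the one carried by compound 1, whose value in this assay is 2240 nM, although compound 1 and compound 3 also differ at another place, so no measured step covers that pair. Among the measured compounds shown here, with no measured step for this exact change, a shift toward a higher number is expected, a 5.8-fold higher number from compound 2 to compound 3 (0.76 log units; beyond the scatter), of a size roughly matching the gap between compound 2 and compound 1. Compound 3 is expected at 1500 nM, with a range of 450 nM to 5000 nM.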

Compound 3, half-maximal inhibitory concentration: 3690 nM
Beside the measured number, compound 3's estimate is 2.5-fold (0.39 log units) below it; low and high end bracket the measured number.
By their numbers in this assay, from the lowest: compound 2; then compounds 1 and 3 (each within the scatter of the next).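

In this assay, 2,6-dimethylphenyl in place of 4-bromophenyl on an aromatic nitrogen is a large change (a 14-fold higher number from compound 2 to compound 3 (1.15 log units; beyond the scatter)), so this position responds strongly to the aryl group it carries. Piperidin-1-yl in place of pyrrolidin-1-yl on the saturated chain carbon gives only a small step by comparison (a 1.6-fold higher number from compound 1 to compound 3 (0.22 log units; within the scatter)), so the two rings cannot be told apart here when 2,6-dimethylphenyl is present. No available evidence bears on the reason for the large step.

Going by these compounds, whether the shift follows loss of the bromine or arrival of the two methyl groups remains open; 4-methylphenyl or unsubstituted phenyl would separate the two. Also open, on these data alone, is whether a morpholine at the chain end would behave like piperidin-1-yl, or whether the ring swap would stay this small with 4-bromophenyl present.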